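This account rests on a few compounds, and the source may have more. Where it says the series, first, only, none or still open, it means among the compounds named here.

In a functional assay on MCF7 cells (Homo sapiens) for cytotoxicity, read by MTT assay, with a stated time of 72 h (on this read-out lower numbers stand for stronger inhibition and higher numbers for weaker inhibition), compound 1 `COc1cc(C=C2C(=O)N(c3ccc(Cl)cc3)N(c3ccc(Cl)cc3)C2=O)cc(OC)c1OC` gives 16200 nM and compound 2 `COc1cccc(C=C2C(=O)N(c3ccc(Cl)cc3)N(c3ccc(Cl)cc3)C2=O)c1O` gives 26700 nM on the same read-out. These two values lie within the usual scatter of each other, so compound 2 stands level with compound 1 on the numbers available. Compound 3 `COc1ccccc1C=C1C(=O)N(c2ccc(Cl)cc2)N(c2ccc(Cl)cc2)C1=O` keeps the shared core and carries 2-methoxyphenyl in place of 2-hydroxy-3-methoxyphenyl on a double-bonded chain carbon bound to a double-bonded ring carbon. Among the compounds with values here, no measured pair of compounds differs in one place only, so the data offer no direct guide to this change. With so little to go on, no step beyond the scatter is expected in this assay in either direction. The expected step is a 1.2-fold lower number from compound 2 to compound 3 (0.08 log units; within the scatter) and it is estimated to stay within the scatter. For compound 3 the estimated value is 22000 nM with 9000 nM to 55000 nM as the expected range.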

Compound 3, half-maximal inhibitory concentration: 26300 nM
Compound 3: the middle estimate sits 1.2-fold (0.08 log units) below what was measured; the range from low to high includes it.
By their numbers in this assay, from the lowest: compounds 1, 3 and 2 (each within the scatter of the next).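

Going from 2-hydroxy-3-methoxyphenyl to 2-methoxyphenyl, on a double-bonded chain carbon bound to a double-bonded ring carbon, gives in this assay a 1.0-fold lower number from compound 2 to compound 3 (0.01 log units; within the scatter), the first reading of a single change in this series. At this place, then, the group can go from 1 hydrogen-bond donor to 0 hydrogen-bond donors, and from 2 hydrogen-bond acceptors to 1 hydrogen-bond acceptor, without any step that can be told from the scatter. No measurement shown here explains this flat result. Going by these compounds, whether an amine or a carboxylic acid in place of the 2-methoxyphenyl would move the number beyond the scatter remains open. On these data alone, it is equally open whether changes elsewhere on the shared core would do so.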